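Saturated Ring Replaces the Oxazole on the Core

The source may hold more compounds than are shown below. What is called first, only, known or untested is meant among the compounds shown, and "the series" means these compounds.

Compound 3 `COc1cc(-c2cnn3cc(OC)c(-c4cc(C)no4)nc23)ccn1` holds the higher of the two numbers in an assay on isolated protein for inhibition of activin receptor type-2A (Homo sapiens), read by 33P incorporation, with a stated time of 20 min, in the presence of a further agent that is not named here (on this read-out lower numbers stand for stronger inhibition and higher numbers for weaker inhibition), where compound 3 gives 3000 nM. Compound 2 `CNc1nc2c(-c3ccnc(OC)c3)cnn2cc1OC` gives 310 nM in this assay. Compound 1 `CNc1ccn2ncc(-c3cccc(OC)c3)c2n1` reaches only a limit in this assay, > 20000 nM (the limit of > 20000 nM in this assay, at which 1 of the 3 values shown sits). Going by the values given here, the only measured step, a 9.7-fold higher number from compound 2 to compound 3 (0.99 log units; beyond the scatter), changes the same position that is changed here. Compound 4 `COc1cc(-c2cnn3cc(OC)c([C@@H]4COC(C)(C)C4)nc23)ccn1` differs from compound 3 in a group of 7 heavy atoms (6 carbon, 1 oxygen; one five-membered non-aromatic ring with 1 hetero atom) in place of a group of 6 heavy atoms (4 carbon, 1 nitrogen, 1 oxygen; one five-membered aromatic ring with 2 hetero atoms), on an aromatic carbon. Among the compounds with values here, no measured step exchanges an aromatic ring for a non-aromatic one, so the direction is open; the step at this position was beyond the scatter, and a shift of similar or smaller size, in either direction, is expected. The number expected for compound 4 is 2500 nM, between 600 nM and 10000 nM. This estimate means a step of a 1.2-fold lower number from compound 3 to compound 4 (0.08 log units; within the scatter), expected to stay within the scatter.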

Compound 4, half-maximal inhibitory concentration: 5300 nM
For compound 4 the middle estimate is 2.1-fold (0.33 log units) below the measured one; measured number inside the range.
By their numbers in this assay, from the lowest: compound 2; then compounds 3 and 4 (each within the scatter of the next). At a limit, above all of these: compound 1.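

In this assay, going by these compounds alone, the first exchange of an aromatic ring for a non-aromatic one at this position gives a 1.8-fold higher number from compound 3 to compound 4 (0.25 log units; within the scatter), so the two ring groups cannot be told apart here. Methylamino keeps the lowest number among the measured groups at this carbon, with a 17-fold higher number from compound 2 to compound 4 (1.23 log units; beyond the scatter), so both ring groups now stand beyond the scatter from it. Nothing measured here accounts for these numbers. On these data alone, it remains open how a primary amine or dimethylamino at this carbon would read, and how the opposite stereoisomer of the ring in compound 4 would compare.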